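The source may hold more compounds than are shown below. What is called first, only, known or untested is meant among the compounds shown, and "the series" means these compounds.

Compound 2 `CC(Sc1nc2c(cnn2C)c(=O)n1-c1ccccc1)c1cccc(O)c1` gives 21000 nM in a physicochemical assay for solubility, using the shake flask method, in phosphate buffer, with a stated time of 24 h, at pH 7.4 (a lower number here means a less soluble compound, a higher number a more soluble compound), the highest of the two numbers in hand. Compound 1 `CC(Sc1nc2c(cnn2C)c(=O)n1-c1ccccc1)c1ccccc1` stands nearest; in this assay compound 1 gives 8000 nM. Among the compounds with values here, the single measured step is a 2.6-fold higher number from compound 1 to compound 2 (0.42 log units; beyond the scatter). Compound 3 `CC(Sc1nc2c(cnn2C)c(=O)n1-c1ccccc1)c1cncnc1` is the next compound to go into this assay. It differs from compound 2 by pyrimidin-5-yl in place of 3-hydroxyphenyl on a saturated chain carbon bound to a saturated chain carbon and a sulfur. Within the data shown here, the one step in hand bears on this change only in part: it shows the hydroxy going in as a 2.6-fold higher number from compound 1 to compound 2 (0.42 log units; beyond the scatter), whereas here that hydroxy leaves and the ring itself is exchanged, a move for which no measured pair exists. The expected step from the hydroxy leaving is thus offset by an unknown contribution from the ring swap, so the estimated step is a 1.2-fold higher number from compound 2 to compound 3 (0.08 log units; within the scatter), within the scatter. For compound 3 the estimate in this assay is 25000 nM, with a range from 8000 nM to 70000 nM.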

Compound 3, solubility: 264000 nM
Estimate against measurement, compound 3: 11-fold (1.02 log units) below; the whole stated range lies below it.
By their numbers in this assay, from the lowest: compound 1; then compound 2; then compound 3.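

Exchanging the ring at this place, on a saturated chain carbon bound to a saturated chain carbon and a sulfur, moves the read-out in this assay much further than adding a hydroxy to the phenyl did: the earlier step was a 2.6-fold higher number from compound 1 to compound 2 (0.42 log units; beyond the scatter) and was modest. Pyrimidin-5-yl gives a 13-fold higher number from compound 2 to compound 3 (1.10 log units; beyond the scatter) and is also set against the unsubstituted phenyl by a 33-fold higher number from compound 1 to compound 3 (1.52 log units; beyond the scatter) so that both of its steps are large and beyond the scatter, placing compound 3 highest of the three. No measurement at hand accounts for the size of these steps.

Open, going by these compounds, is how much of the step a pyridyl ring, with a single ring nitrogen, would retain at this place. Also open, on these data alone, is how an amine or a carboxylic acid on the phenyl would compare with the pyrimidin-5-yl.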